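The source may report more compounds than this note shows. Statements on the series, on what has been measured and on what is new or still open speak of the compounds shown alone.

Measured so far in a functional assay on SR cells (Homo sapiens) for inhibition, read by sulforhodamine B assay, with a stated time of 48 h; on this read-out higher numbers stand for weaker inhibition of growth and lower numbers for stronger inhibition of growth:
compound 1 `O=C(Nc1cccc(-n2cc(-c3ccncc3)c(-c3ccc(Cl)c(O)c3)n2)c1)Nc1cccc(C(F)(F)F)c1` gives 1820 nM;
compound 2 `O=C(Nc1cccc(-n2cc(-c3ccncc3)c(-c3ccc(Cl)c(O)c3)n2)c1)Nc1ccc(Cl)c(Cl)c1` gives 1140 nM;
compound 3 `COc1cc(-c2nn(-c3cccc(NC(=O)Nc4cccc(C(F)(F)F)c4)c3)cc2-c2ccncc2)ccc1Cl` gives 886 nM.

For the measured compounds named here, compound 1 stands at the upper end of these three numbers, but its step to compound 2 a 1.6-fold lower number from compound 1 to compound 2 (0.20 log units; within the scatter) lies within the scatter, and only the step to compound 3 a 2.1-fold lower number from compound 1 to compound 3 (0.31 log units; beyond the scatter) reaches beyond it, and modestly. Compound 4 `O=C(Nc1cccc(-n2cc(-c3ccncc3)c(-c3ccc(Cl)c(O)c3)n2)c1)Nc1cc(C(F)(F)F)cc(C(F)(F)F)c1` differs from compound 1 by trifluoromethyl in place of hydrogen on an aromatic carbon. The step that bears on this is the exchange at the same amide-type nitrogen a 1.6-fold lower number from compound 1 to compound 2 (0.20 log units; within the scatter), which left the number essentially unchanged. A second trifluoromethyl group is therefore expected to give a step of a 1.2-fold lower number from compound 1 to compound 4 (0.08 log units; within the scatter) of no more than the scatter in this assay. The estimate for compound 4 is 1500 nM, within 600 nM to 4000 nM.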

Compound 4, concentration for 50% growth inhibition: 922 nM
Compound 4: the middle estimate sits 1.6-fold (0.21 log units) above what was measured, and the stated range covers the measured number.
By their numbers in this assay, from the lowest: compounds 3, 4, 2 and 1 (each within the scatter of the next, the first and the last beyond it).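

On the ring carrying the trifluoromethyl group of compound 1, a second trifluoromethyl group on an aromatic carbon gives a 2.0-fold lower number from compound 1 to compound 4 (0.30 log units; within the scatter) in this assay, so no real difference in growth inhibition can be claimed. For the compounds shown here, this position therefore accepts this much larger group than hydrogen with no step beyond the scatter, something the earlier compounds did not show. Nothing shown gives a reason for this result. Still open, as far as these compounds go, is whether an amine or a carboxylic acid on this same aromatic carbon would also leave the number within the scatter.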